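From 2-bromophenyl to 4-cyanophenyl on the sulfonyl sulfur

A few compounds are considered here, and "the series" means these few. Any claim that something is new, unique, unknown or untested is made for them only; others in the source may bear on it.

Compound 2 `O=C(O)CC(NS(=O)(=O)c1ccccc1Br)c1ccc(Cl)cc1Cl` reads > 100000 nM in a functional assay on MDA-MB-436 cells (Homo sapiens) for antiproliferative activity, read by MTT assay, with a stated time of 24 h (on this read-out lower numbers stand for stronger inhibition and higher numbers for weaker inhibition), and this is a limit of the assay, not a number. Among the compounds with values here, compound 1 `N#Cc1ccc(S(=O)(=O)NC(CC(=O)O)c2ccccc2F)cc1` gives a measured 77700 nM in this assay and is the only number available so far.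

The next compound is compound 3 `N#Cc1ccc(S(=O)(=O)NC(CC(=O)O)c2ccc(Cl)cc2Cl)cc1`, which differs from compound 2 by one change: 4-cyanophenyl in place of 2-bromophenyl on a sulfonyl sulfur. In words, this is 4-cyanophenyl in place of 2-bromophenyl on a sulfonyl sulfur. Within the data shown here, no measured step sizes this change.

Compound 1 also carries 4-cyanophenyl on a sulfonyl sulfur and gives 77700 nM in this assay, so a modest move towards stronger inhibition is expected. The expected step of an at least 1.4-fold lower number from compound 2 to compound 3 (0.15 log units; that floor lies within the scatter) is small and may stay within the scatter. For compound 3 the estimated value is 70000 nM, with an expected range from 30000 nM to 100000 nM as the estimate.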

Compound 3, half-maximal inhibitory concentration: 19800 nM
The estimate for compound 3 lay 3.5-fold (0.55 log units) above the measured number; the measured number lies below the stated range.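

In this assay 4-cyanophenyl in place of 2-bromophenyl on the sulfonyl sulfur gives an at least 5.0-fold lower number from compound 2 to compound 3 (0.70 log units; beyond the scatter) and so gives this change its first size, with 2,4-dichlorophenyl held on the chain carbon. Compound 2 gives a limit of the assay and not a number, so that step is only a floor: the limit of > 100000 nM in this assay, at which 1 of the 3 values shown sits. With 4-cyanophenyl held on the sulfonyl sulfur, 2,4-dichlorophenyl in place of 2-fluorophenyl gives a 3.9-fold lower number from compound 1 to compound 3 (0.59 log units; beyond the scatter) and shows that the read-out also answers to the group on the chain carbon.

The compounds shown leave open whether the step to 4-cyanophenyl holds with 2-fluorophenyl on the chain carbon, and how much of it belongs to the nitrile rather than to the position on the phenyl ring. From the compounds shown here alone, how a 4-methoxyphenyl or a pyridyl group on the sulfonyl sulfur would read in this assay also stays open.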